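This account rests on a few compounds, and the source may have more. Where it says the series, first, only, none or still open, it means among the compounds named here.

In an assay on cells for inhibition of Amine oxidase [flavin-containing] B (Homo sapiens), read by fluorescence, with stated times of 30 min and 15 min, tested at 1 uM (on this read-out higher numbers stand for more inhibition at the one concentration tested (going by the name of the read-out) and lower numbers for less inhibition), compound 2, `CCn1c(=O)[nH]c2ccc(OCCOc3ccc(OC)cc3)cc21`, gives 13.9%, the second highest of the three numbers recorded there. Compound 1, `COc1ccc(OCCOc2ccc3[nH]c(=O)n(C(C)C)c3c2)cc1`, gives 15.5%, and compound 3, `Cn1c(=O)[nH]c2ccc(OCc3ccc(Cl)cc3)cc21`, gives 8.29%; both of these gaps lie within the scatter, so the three compounds are not separated on this read-out. Within the data shown here, the one measured step, a number 1.6 percentage points lower from compound 1 to compound 2 (within the scatter), concerns the substituent on the nitrogen of the shared core and not the distal aromatic ring. Compound 4, `CCn1c(=O)[nH]c2ccc(OCCOc3ccc(C(C)C)cc3)cc21`, carries isopropyl in place of methoxy on an aromatic carbon. Among the measured compounds shown here, no measured step touches that position, so nothing in the data points to a shift beyond the scatter, and compound 4 is expected to show a number 0.1 percentage points higher from compound 2 to compound 4 (within the scatter). Compound 4 is therefore estimated at 14%, between 3% and 30%.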

Compound 4, a percentage reported as inhibition, at one concentration (the size of the read-out at that concentration, not a potency): 19%
Beside the measured number, compound 4's estimate is 5 percentage points below it; the measured number falls inside the stated range.
By their numbers in this assay, from the lowest: compounds 3, 2, 1 and 4 (each within the scatter of the next, the first and the last beyond it).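

Among these compounds, the first step at this position, on an aromatic carbon para to a large group, reads in this assay as a number 5.1 percentage points higher from compound 2 to compound 4 (within the scatter). Replacing the methoxy with the all-carbon isopropyl therefore does not separate the two compounds on this read-out, so the oxygen of the methoxy is not shown to matter here. No evidence is available to account for this step. As far as these compounds go, it remains open whether an amine or a carboxylic acid at this position would move the number beyond the scatter. The same question stands for a longer chain in place of the isopropyl.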